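The compounds below may be only part of what the source reports. "The series", "measured", "known", "first", "only" and "open" are said of these compounds alone.

Measured compounds:
compound 1, `O=C(Nc1cccc(-c2oc3cc(-c4ccc(F)cc4)ccc3c(=O)c2O)c1)c1ccc(F)cc1`, 5350 nM
compound 2, `Cc1ccc(C(=O)Nc2cccc(-c3oc4cc(-c5ccc(F)cc5)ccc4c(=O)c3O)c2)cc1`, 6190 nM
compound 3, `O=C(Nc1cccc(-c2oc3cc(-c4ccc(F)cc4)ccc3c(=O)c2O)c1)c1ccc(Br)cc1`, 9740 nM

In a functional assay on HeLa cells (Homo sapiens) for antiproliferative activity, read by CCK-8 assay, with a stated time of 72 h (on this read-out lower numbers stand for stronger inhibition and higher numbers for weaker inhibition), compound 3 gives the highest of the three numbers, but its separation from the others is small: a 1.8-fold higher number from compound 1 to compound 3 (0.26 log units; within the scatter) and a 1.6-fold higher number from compound 2 to compound 3 (0.20 log units; within the scatter) both lie within the scatter, as does a 1.2-fold higher number from compound 1 to compound 2 (0.06 log units; within the scatter). On these figures the three compounds cannot be put in any order of potency.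

Compound 4, `Cc1cccc(C(=O)Nc2cccc(-c3oc4cc(-c5ccc(F)cc5)ccc4c(=O)c3O)c2)c1`, has not yet been measured in this assay. It differs from compound 3 by 3-methylphenyl in place of 4-bromophenyl on a carbonyl carbon. The measured steps that bear on it are the exchanges on the same aromatic carbon of the benzamide: methyl in place of fluoro, bromo in place of fluoro and bromo in place of methyl, none of which moved the number beyond the scatter. Among the compounds with values here, no measured step places a methyl as 3-methylphenyl, so the closest guide is the reverse of the bromo-for-methyl exchange, which would point to a somewhat lower number. Compound 4 is therefore expected to give about 6500 nM in this assay, in the range 3300 nM to 13000 nM, a step of a 1.5-fold lower number from compound 3 to compound 4 (0.18 log units; within the scatter) that is not expected to exceed the scatter.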

Compound 4, half-maximal inhibitory concentration: 6650 nM
Compound 4: middle estimate off by 1.0-fold (0.01 log units), on the low side, within the range that was stated.
By their numbers in this assay, from the lowest: compounds 1, 2, 4 and 3 (each within the scatter of the next).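

Among the compounds shown, only compound 4 carries 3-methylphenyl on the carbonyl carbon, while the others carry 4-fluorophenyl, 4-methylphenyl or 4-bromophenyl, so this result adds a change in where the methyl sits to the earlier exchanges of one group for another on the same carbon. In this assay, that change of place gives a 1.1-fold higher number from compound 2 to compound 4 (0.03 log units; within the scatter), and the exchanges against the other two groups give a 1.5-fold lower number from compound 3 to compound 4 (0.17 log units; within the scatter) and a 1.2-fold higher number from compound 1 to compound 4 (0.09 log units; within the scatter); all three steps lie within the scatter, so neither the place of the methyl nor these exchanges separate compound 4 from the other three compounds. Nothing given here speaks to why these four numbers lie so close together.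

The compounds shown leave open whether any group on this phenyl ring, such as an amine, a carboxylic acid or a methoxy group, would give a step beyond the scatter. They also leave open what would follow if a longer alkyl chain or a pyridine ring took the place of the whole aryl group on the carbonyl carbon.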